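Chloro for hydrogen on the core of compound 1

The source may report more compounds than this note shows. Statements on the series, on what has been measured and on what is new or still open speak of the compounds shown alone.

Measured so far:
compound 1 `c1cncc(-c2nc3ccccc3n2C2CC2)c1` gives 49 nM in an assay on V79 cells for inhibition of cytochrome P450 11B2, mitochondrial (Homo sapiens), read by HTRF, with a stated time of 1 h; a higher number here means a weaker inhibitor, a lower number a stronger inhibitor
compound 2 `Fc1cccc2nc(-c3cccnc3)n(C3CC3)c12` gives 107 nM in this assay

Compound 1 holds the lowest of the two numbers in this assay; its nearest neighbour is compound 2, and the step of a 2.2-fold higher number from compound 1 to compound 2 (0.34 log units; beyond the scatter) lies beyond the scatter, so the halogen in compound 2 comes with a modest loss.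

Compound 3 `Clc1ccc2nc(-c3cccnc3)n(C3CC3)c2c1` has not yet been measured. It differs from compound 1 by chloro in place of hydrogen on an aromatic carbon. Within the data shown here, the only measured step that bears on this change is the one from compound 1 to compound 2, where a fluoro in place of hydrogen on an aromatic carbon of the core gave a 2.2-fold higher number from compound 1 to compound 2 (0.34 log units; beyond the scatter). Compound 3 also introduces a halogen on an aromatic carbon of the core, so a step of similar size, in the weakening direction, is expected, though it could also stay within the scatter. The step from compound 1 to compound 3 in this assay is therefore expected to be a 1.7-fold higher number from compound 1 to compound 3 (0.24 log units; within the scatter). Compound 3 is estimated to give 85 nM in this assay, within a range from 35 nM to 210 nM.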

Compound 3, half-maximal inhibitory concentration: 2.2 nM
For compound 3 the middle estimate is 39-fold (1.59 log units) above the measured one; measured number below the stated range.
By their numbers in this assay, from the lowest: compound 3; then compound 1; then compound 2.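

In this assay chloro in place of hydrogen on this aromatic carbon of the core gives a 22-fold lower number from compound 1 to compound 3 (1.35 log units; beyond the scatter) and thus shows that one added chlorine atom can move the number by a large step, in the opposite direction to a 2.2-fold higher number from compound 1 to compound 2 (0.34 log units; beyond the scatter) seen with the fluoro of compound 2. A halogen on the core therefore has no single direction across these compounds, and since compound 2 and compound 3 carry different halogens on different carbons, the two steps cannot separate the identity of the halogen from its place. No measured evidence accounts for the size of the step to compound 3.

The compounds shown leave open whether the gain belongs to chloro itself or to this carbon, a question that fluoro, bromo, methyl or nitrile on the same carbon, or chloro on the carbon that bears fluoro in compound 2, would address. They also leave open how this chloro behaves when the cyclopropyl group is replaced by a longer chain or the pyridine ring by another group.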